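The compounds below may be only part of what the source reports. "The series", "measured", "known", "first", "only" and "open" are said of these compounds alone.

Of the compounds shown here, three have been measured in a functional assay on CHO cells for antagonist activity at Orexin/Hypocretin receptor type 1 (Homo sapiens), read by FLIPR and calcium flux; on this read-out lower numbers stand for stronger inhibition and higher numbers for weaker inhibition. Compound 1 `CCn1nc(C)c2c1CCN(C(C(=O)NC)c1ccccc1)C2CCc1cccc(C)c1` gives 180 nM, the lowest of the three numbers and so the strongest inhibition seen in this set. Compound 3 `CCn1nc(C)c2c1CCN([C@@H](C(=O)NC)c1ccccc1)[C@@H]2CCc1ccc(C(C)C)cc1` gives 1920 nM, and compound 2 `CCn1nc(C)c2c1CCN([C@@H](C(=O)NC)c1ccccc1)[C@H]2COc1ccc(C)cc1` gives 10000 nM; both gaps from compound 1 lie beyond the usual scatter of repeated measurements.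

Compound 4 `CCn1nc(C)c2c1CCN(C(C(=O)NC)c1ccccc1)C2CCc1cccc(F)c1` has not yet been measured. It differs from compound 1 in a single place: fluoro in place of methyl on an aromatic carbon. The change sits on an aromatic carbon of a six-membered aromatic ring of carbon only, meta to a large group. Among the compounds with values here, none of the measured pairs in this set shows the same exchange, so there is no direct reference for how large a step it brings.

In the absence of such a reference, the step expected in this assay is a 1.7-fold higher number from compound 1 to compound 4 (0.22 log units; within the scatter), a small shift that may well fall within the scatter. Compound 4 is therefore estimated at 300 nM, with a plausible range from 100 nM to 900 nM.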

Compound 4, half-maximal inhibitory concentration: 402 nM
Estimate against measurement, compound 4: 1.3-fold (0.13 log units) below, and the stated range covers the measured number.
By their numbers in this assay, from the lowest: compound 1; then compound 4; then compound 3; then compound 2.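

In this assay, within the data shown here, this is the first direct look at what this aromatic carbon tolerates: fluoro in place of methyl gives a 2.2-fold higher number from compound 1 to compound 4 (0.35 log units; beyond the scatter). The exchange swaps one heavy atom for another and adds no ring, no hydrogen-bond donor or acceptor and no charge, yet the step is modest and still lies beyond the scatter, with methyl giving the stronger inhibition of the two. So the group at this carbon has a readable influence on inhibition, although nothing shown here gives a cause for the step.

Among these compounds, the pair alone cannot show whether methyl is favoured over other groups here, since no compound carries chloro, methoxy or a nitrile on this carbon, or simply hydrogen. It also leaves open whether the same exchange would give a similar step on another carbon of this ring.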